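Pyridinylmethyl amide replacing imidazolylpropyl amide in a pyrimidine series

The source may report more compounds than this note shows. Statements on the series, on what has been measured and on what is new or still open speak of the compounds shown alone.

Measured compounds:
Compound 1, `Cc1cccc(Oc2ccnc(N3CCC[C@H]3C(=O)NCCCn3ccnc3)n2)c1`: 0%
Compound 2, `O=C(CN1CCN(c2ncnc3c2CN(Cc2ccccc2)CC3)CC1)Nc1cc(F)ccc1F`: 0%
Compound 3, `Cc1cccc(N(C)c2cc(Nc3cccc(C(=O)N4CCCC5CCCCC54)c3)ncn2)c1`: 8%

All three were run in an assay on isolated protein for inhibition of vascular endothelial growth factor receptor 1 (Homo sapiens), read by HTRF, tested at 10 uM; a lower number here means less inhibition, a higher number more inhibition at the concentration tested (going by the name of the read-out). Compound 1 gives 0% and stands level with compound 2, which gives 0%. Compound 3, which gives 8%, lies within the scatter of both, so the three numbers cannot be told apart. Nothing in this set shows a step that rises beyond the scatter.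

The untested compound 4, `Cc1cccc(Oc2ccnc(N3CCC[C@H]3C(=O)NCc3cccnc3)n2)c1`, is made from compound 1 by one change: pyridin-3-yl in place of 2-(1H-imidazol-1-yl)ethyl on a saturated chain carbon bound to an amide-type nitrogen. The shared core of compound 1 and compound 4 is left as it is, and the amide itself is kept; only the group on the saturated chain carbon bound to the amide-type nitrogen is exchanged.

Going by the values given here, with no step between measured compounds available, the expectation rests on the level of compound 1 alone. The step of a number 2 percentage points higher from compound 1 to compound 4 (within the scatter) is expected to be none beyond the scatter. For compound 4 the estimated value in this assay is 2%, expected to fall between -8% and 12%.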

Compound 4, a percentage reported as inhibition, at one concentration (the size of the read-out at that concentration, not a potency): 0%
Estimate against measurement, compound 4: 2 percentage points above; the measured number falls inside the stated range.
By their numbers in this assay, from the lowest: compounds 1, 2, 4 and 3 (each within the scatter of the next).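

Pyridin-3-yl in place of 2-(1H-imidazol-1-yl)ethyl on a saturated chain carbon bound to an amide-type nitrogen gives no change at the digits printed from compound 1 to compound 4 (within the scatter) in this assay and is the only single-place step readable in this set. At this position, a five-membered aromatic ring with 2 hetero atoms and a six-membered aromatic ring with 1 hetero atom therefore cannot be told apart, though both ends of the step read no inhibition, so the step cannot show what the group does where inhibition is present. No supporting measurement bears on this result.

Left open is whether an amine, a carboxylic acid or a longer chain at this position would give a number beyond the scatter in this assay and not merely within it. Also open, going by these compounds, is whether the same exchange would read differently on a compound whose number stands beyond the scatter of compound 1.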